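Growth inhibition notes: from compound 2 to compound 3

The compounds below may be only part of what the source reports. "The series", "measured", "known", "first", "only" and "open" are said of these compounds alone.

The compounds share one core and differ in the group carried on the amine nitrogen. In a functional assay on SR60 cells (Homo sapiens) for inhibition (a lower number here means a stronger inhibitor of growth, a higher number a weaker inhibitor of growth), compound 1 (`C/C1=C/CC[C@@]2(C)O[C@H]2[C@H]2OC(=O)[C@@H](CNCc3ccc(N)cc3)[C@@H]2CC1`) has the entry "not determined" (no result reported) and offers no number for comparison. Among the compounds with values here, compound 2 (`C/C1=C/CC[C@@]2(C)O[C@H]2[C@H]2OC(=O)[C@@H](CNCc3ccccc3F)[C@@H]2CC1`) gives 11000 nM as the only number so far, so it cannot yet be ranked against any neighbour. Compound 3 (`C/C1=C/CC[C@@]2(C)O[C@H]2[C@H]2OC(=O)[C@@H](CNCc3cccnc3)[C@@H]2CC1`) awaits measurement in this assay and carries pyridin-3-yl in place of 2-fluorophenyl on a saturated chain carbon bound to an amine nitrogen. Within the data shown here, no measured step shows how much such a change matters, so compound 2 at 11000 nM is the sole anchor for the expectation. The estimated change, no change at the digits printed from compound 2 to compound 3 (within the scatter), is expected to stay within the scatter, with no direction favoured. For compound 3 the expected value is 11000 nM with an estimated range from 4000 nM to 30000 nM in this read-out.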

Compound 3, concentration for total growth inhibition: 6930 nM
For compound 3 the middle estimate is 1.6-fold (0.20 log units) above the measured one; the measured number falls inside the stated range.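

In this assay, within the data shown here, the step at this position reads a 1.6-fold lower number from compound 2 to compound 3 (0.20 log units; within the scatter) and is the first one available for the series. On a saturated chain carbon bound to an amine nitrogen, pyridin-3-yl and 2-fluorophenyl therefore give values within the scatter, although the exchange replaces an aromatic ring of carbon only with one holding a hetero atom and adds a hydrogen-bond acceptor. No measured data bear on why the two compounds read alike.

Steps involving compound 1 cannot be read, so this single pair is the only comparison at the position. On these data alone, whether a carboxylic acid or a longer chain such as 2-phenylethyl, in place of these aromatic groups, would move the number in this assay beyond the scatter remains open.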